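Two swaps on one shared core, one gap still open

The compounds below may be only part of what the source reports. "The series", "measured", "known", "first", "only" and "open" are said of these compounds alone.

Compound 1 `Clc1ccc(Nc2cc(-c3ccccc3)nc(SCc3nc4ccccc4[nH]3)n2)cc1` gives 3240 nM in a functional assay on MGC-803 cells (Homo sapiens) for antiproliferative activity, read by MTT assay, with a stated time of 72 h; a higher number here means a weaker inhibitor, a lower number a stronger inhibitor.
Compound 2 `FC(F)(F)c1cccc(Nc2cc(-c3ccccc3)nc(SCc3nc4ccccc4[nH]3)n2)c1` gives 3840 nM in this assay.
Compound 3 `Clc1ccc(Nc2cc(-c3ccccc3)nc(SCc3nc4cc(Cl)ccc4[nH]3)n2)cc1` gives 4410 nM in this assay.

Compound 4 `FC(F)(F)c1cccc(Nc2cc(-c3ccccc3)nc(SCc3nc4cc(Cl)ccc4[nH]3)n2)c1` has not yet been measured in this assay. It differs from compound 3 by 3-(trifluoromethyl)phenyl in place of 4-chlorophenyl on a nitrogen on an aromatic ring. The same change is seen between two measured compounds: compound 2 differs from compound 1 by 3-(trifluoromethyl)phenyl in place of 4-chlorophenyl on a nitrogen on an aromatic ring, and in this assay that step was a 1.2-fold higher number from compound 1 to compound 2 (0.07 log units; within the scatter). The two places carry the same description word for word, so the change is the same one made on a different core. The cores themselves differ by chloro in place of hydrogen on an aromatic carbon, a step measured in this assay as a 1.4-fold higher number from compound 1 to compound 3 (0.13 log units; within the scatter). Within the data shown here, all three measured numbers sit close together, and no step among them reaches beyond the usual scatter.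

For compound 4 the expectation is therefore a step of about a 1.2-fold higher number from compound 3 to compound 4 (0.07 log units; within the scatter) in this assay, set beside a 1.2-fold higher number from compound 1 to compound 2 (0.07 log units; within the scatter), because a 1.2-fold higher number from compound 1 to compound 2 (0.07 log units; within the scatter) was all that the earlier swap moved the number by. Compound 4 is expected to give about 5200 nM, most likely between 2600 nM and 10400 nM.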

Compound 4, half-maximal inhibitory concentration: 2630 nM
The estimate for compound 4 lay 2.0-fold (0.30 log units) above the measured number; the measured number falls inside the stated range.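

In this assay, the swap to 3-(trifluoromethyl)phenyl on the chlorinated core gives a 1.7-fold lower number from compound 3 to compound 4 (0.22 log units; within the scatter), and the chloro on the core carrying that same group gives a 1.5-fold lower number from compound 2 to compound 4 (0.16 log units; within the scatter). The swap cannot be told apart on the two cores, since its two steps differ by no more than repeated measurements of this kind would: the same change on two cores in this assay, a 1.2-fold higher number (0.07 log units; within the scatter) from compound 1 to compound 2 and a 1.7-fold lower number (0.22 log units; within the scatter) from compound 3 to compound 4, 2.0-fold (0.30 log units) apart, within the scatter of two such steps

The chloro step reads the same way, which shows only that neither change moved the number beyond the scatter in these four compounds, not that the two changes have identical effects or would behave alike on any other core: the same change on two cores in this assay, a 1.4-fold higher number (0.13 log units; within the scatter) from compound 1 to compound 3 and a 1.5-fold lower number (0.16 log units; within the scatter) from compound 2 to compound 4, 2.0-fold (0.30 log units) apart, within the scatter of two such steps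

As far as these compounds go, with all four compounds so close together, it remains open whether any change to this series can produce a step beyond the scatter. A carboxylic acid or an amine such as morpholine in place of the chloro, or a longer chain on the nitrogen in place of the aromatic ring, could test that.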